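The compounds below may be only part of what the source reports. "The series", "measured", "known", "first", "only" and "open" are said of these compounds alone.

Of the compounds shown here, three with a shared core have been measured in a functional assay on HeLa cells (Homo sapiens) for antiproliferative activity, with a stated time of 24 h; on this read-out lower numbers stand for stronger inhibition and higher numbers for weaker inhibition. Compound 1 `NC(=O)c1c(NC(=O)c2ccccc2Cl)sc2c1CCN(Cc1ccccc1Cl)C2` gives 27500 nM. Compound 2 `NC(=O)c1c(NC(=O)c2ccccc2F)sc2c1CCN(Cc1c(Cl)cccc1Cl)C2` gives 33000 nM, and compound 3 `NC(=O)c1c(NC(=O)c2cccc([N+](=O)[O-])c2)sc2c1CCN(Cc1c(Cl)cccc1Cl)C2` gives 46100 nM. The three numbers lie close together: the gap from compound 1 to compound 2 and the gap from compound 1 to compound 3 are both within the usual scatter, so compound 1 cannot be told apart from the other two on this read-out. Within the data shown here, the one step between neighbours that differ in a single place, a 1.4-fold higher number from compound 2 to compound 3 (0.15 log units; within the scatter), also stays within the scatter.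

Compound 4 `COc1ccccc1NC(=S)N1CCc2c(sc(NC(=O)c3ccccc3Cl)c2C(N)=O)C1` has not been measured. It differs from compound 1 at the amine nitrogen in the ring, (a group of 11 heavy atoms (8 carbon, 1 nitrogen, 1 oxygen, 1 sulfur; one six-membered aromatic ring of carbon only) in place of a group of 8 heavy atoms (7 carbon, 1 chlorine; one six-membered aromatic ring of carbon only), on an amine nitrogen in a ring).

Among the measured compounds shown here, no measured step touches this position; the only step known, that from compound 2 to compound 3, concerns the group on the carbonyl carbon and was within the scatter. The data therefore give no ground for a directed expectation at the amine nitrogen, and any estimate must rest on the level common to compounds 1, 2 and 3. Compound 4 is expected to give about 25000 nM in this assay, between 7000 nM and 90000 nM, which means an expected step of a 1.1-fold lower number from compound 1 to compound 4 (0.04 log units; within the scatter).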

Compound 4, half-maximal inhibitory concentration: > 50000 nM
Compound 4: a limit, no number; the forecaster's own chance of this, stated with the estimate: 15%; middle value at least 2.0-fold (0.30 log units) away from the limit.
By their numbers in this assay, from the lowest: compounds 1, 2 and 3 (each within the scatter of the next). At a limit, above all of these: compound 4.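

In this assay compound 4 gives > 50000 nM, which is a limit of the assay and not a number. Among these compounds, this is the first reading at the amine nitrogen in the ring: putting the group of 11 heavy atoms, with its sulfur, nitrogen and oxygen, in place of 2-chlorobenzyl gives an at least 1.8-fold higher number from compound 1 to compound 4 (0.25 log units; that floor lies within the scatter), so the change brings no sign of a gain, although the floor of that step does not by itself set the two compounds apart. The true size of the step stays unknown, and what is learned about this position rests on a single value at the limit: the limit of > 50000 nM in this assay, at which 1 of the 4 values shown sits.

Still open, as far as these compounds go, is how a plain benzyl, an acetyl group, or the same entering group with oxygen in place of sulfur would stand on this amine nitrogen. Also open, from the compounds shown here alone, is whether the same replacement would read alike with the 3-nitrophenyl of compound 3 on the carbonyl carbon.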